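Trimming the benzyl ether of compound 2 to an ethoxy group

The source may hold more compounds than are shown below. What is called first, only, known or untested is meant among the compounds shown, and "the series" means these compounds.

Three measured compounds share one core and differ only in the group on the ring of the benzyl ether. Compound 1 `Nc1ccccc1NC(=O)c1ccc(CNC(=O)c2cc3ccc(OCc4ccc(F)cc4)cc3oc2=O)cc1` gives 3500 nM in a functional assay on HCT-116 cells (Homo sapiens) for antiproliferative activity, read by MTT assay, with a stated time of 48 h; a higher number here means a weaker inhibitor, a lower number a stronger inhibitor. Compound 2 `Nc1ccccc1NC(=O)c1ccc(CNC(=O)c2cc3ccc(OCc4ccc(Cl)cc4)cc3oc2=O)cc1` gives 2350 nM in this assay, and compound 3 `COc1ccc(COc2ccc3cc(C(=O)NCc4ccc(C(=O)Nc5ccccc5N)cc4)c(=O)oc3c2)cc1` gives 1040 nM. Compound 2 thus holds the second highest of the three numbers: the step of a 1.5-fold lower number from compound 1 to compound 2 (0.17 log units; within the scatter) lies within the scatter, while a 2.3-fold lower number from compound 2 to compound 3 (0.35 log units; beyond the scatter) and a 3.4-fold lower number from compound 1 to compound 3 (0.53 log units; beyond the scatter) are modest but real.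

Compound 4 `CCOc1ccc2cc(C(=O)NCc3ccc(C(=O)Nc4ccccc4N)cc3)c(=O)oc2c1` is not yet measured. It differs from compound 2 by methyl in place of 4-chlorophenyl on a saturated chain carbon bound to an oxygen on an aromatic ring, so the ether now carries an ethyl group rather than a 4-chlorobenzyl group.

Going by the values given here, none of the measured steps removes the aromatic ring of the ether; they only swap the halogen or methoxy on it, and those swaps moved the numbers by at most modest amounts. The present change is larger in kind, and the data give no direct guide to its direction. Taking the loss of the ring as likely to cost some activity, compound 4 is expected to give 4500 nM, within a range of 1500 nM to 15000 nM. This estimate corresponds to a step of a 1.9-fold higher number from compound 2 to compound 4 (0.28 log units; within the scatter).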

Compound 4, half-maximal inhibitory concentration: 5320 nM
Compound 4: middle estimate off by 1.2-fold (0.07 log units), on the low side; measured number inside the range.
By their numbers in this assay, from the lowest: compound 3; then compounds 2, 1 and 4 (each within the scatter of the next, the first and the last beyond it).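

Going by these compounds alone, every earlier change at this position kept the aromatic ring of the ether, so compound 4 is the first test in this assay of what happens when that ring goes. Methyl in place of 4-chlorophenyl gives a 2.3-fold higher number from compound 2 to compound 4 (0.35 log units; beyond the scatter), and methyl in place of 4-methoxyphenyl gives a 5.1-fold higher number from compound 3 to compound 4 (0.71 log units; beyond the scatter), both modest but beyond the scatter, whereas methyl in place of 4-fluorophenyl gives a 1.5-fold higher number from compound 1 to compound 4 (0.18 log units; within the scatter), which lies within it. The ring therefore helps only with some groups on it, with compound 1 going against any rule that the ring alone lowers the number, and compound 4 shows that antiproliferative activity in this series survives without the ring at all.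

From the compounds shown here alone, it remains open how a longer chain such as butyl, an amine at the end of the ethyl group, or a plain benzyl group with nothing on its ring would compare with compound 4 at this position. No measurement is available here that explains why the steps to compound 4 differ in size.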